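A propyl addition from compound 2 to compound 3

The source may report more compounds than this note shows. Statements on the series, on what has been measured and on what is new or still open speak of the compounds shown alone.

Measured in a functional assay on MGC-803 cells (Homo sapiens) for inhibition, read by MTT assay; on this read-out higher numbers stand for weaker inhibition and lower numbers for stronger inhibition:
- compound 1 `C=C1C(=O)[C@@]23C(=O)OC[C@]4([C@@H](OC(C)=O)CCC(C)(C)[C@H]4C=O)[C@@H]2CC[C@H]1[C@H]3OC(=O)CC`: 3220 nM
- compound 2 `C=C1C(=O)[C@@]23C(=O)OC[C@]4([C@@H](OC(C)=O)CCC(C)(C)[C@H]4C=O)[C@@H]2CC[C@H]1[C@H]3OC(C)=O`: 3470 nM

In this assay, compound 2 at 3470 nM lies within the scatter of compound 1 at 3220 nM. Compound 3 `C=C1C(=O)[C@@]23C(=O)OC[C@]4([C@@H](OC(C)=O)CCC(C)(C)[C@H]4C=O)[C@@H]2CC[C@H]1[C@H]3OC(=O)CCCC` carries propyl in place of hydrogen on a saturated chain carbon bound to a carbonyl carbon. Going by the values given here, the only measured step at this place is a 1.1-fold higher number from compound 1 to compound 2 (0.03 log units; within the scatter), which involves methyl and hydrogen, so it covers a smaller change and gives only limited guidance for propyl. No step beyond the scatter is therefore expected, and the estimated step is a 1.2-fold lower number from compound 2 to compound 3 (0.08 log units; within the scatter). Compound 3 is expected at 2900 nM, with an estimated range of 1400 nM to 6000 nM.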

Compound 3, half-maximal inhibitory concentration: 2490 nM
The estimate for compound 3 lay 1.2-fold (0.07 log units) above the measured number; low and high end bracket the measured number.
By their numbers in this assay, from the lowest: compounds 3, 1 and 2 (each within the scatter of the next).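

In this assay, the acetyl-bearing position takes a much longer chain than the earlier pair covered: methyl to butyl gives a 1.4-fold lower number from compound 2 to compound 3 (0.14 log units; within the scatter) and the smaller extension gives a 1.3-fold lower number from compound 1 to compound 3 (0.11 log units; within the scatter) in the same series. The numbers therefore remain within the scatter across acetyl, the ester in compound 1 and butylcarbonyl, so chain growth up to butyl shows no measurable effect here. Nothing available explains this flat response. Still open, as far as these compounds go, is whether a longer chain, a phenyl ring or a terminal amine or carboxylic acid at this position would move the number beyond the scatter.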